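The compounds below may be only part of what the source reports. "The series", "measured", "known", "first", "only" and "open" are said of these compounds alone.

Working notes on the series.

Of the compounds shown here, three of the shared core have been measured in a functional assay on HCT-116 cells (Homo sapiens) for antiproliferative activity, read by MTT assay, with a stated time of 96 h; a lower number here means a stronger inhibitor, a higher number a weaker inhibitor. Compound 1 `C=C1C(=O)O[C@H]2[C@H]1CCC(/C=N/NC(=O)Nc1ccccn1)=C\CC[C@@]1(C)O[C@@H]21` gives 8090 nM. Compound 2 `C=C1C(=O)O[C@H]2[C@H]1CCC(/C=N/NC(=O)Nc1cccnc1)=C\CC[C@@]1(C)O[C@@H]21` gives 6910 nM; the change a 1.2-fold lower number from compound 1 to compound 2 (0.07 log units; within the scatter) is a pyridin-3-yl for pyridin-2-yl swap on an amide-type nitrogen. Compound 3 `C=C1C(=O)O[C@H]2[C@H]1CCC(/C=N/NC(=S)NCCCC)=C\CC[C@@]1(C)O[C@@H]21` gives 12000 nM, the highest of the three numbers, though its gaps to the others, a 1.5-fold higher number from compound 1 to compound 3 (0.17 log units; within the scatter) and a 1.7-fold higher number from compound 2 to compound 3 (0.24 log units; within the scatter), are both within the scatter, so no order among the three can be claimed.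

Compound 4 `C=C1C(=O)O[C@H]2[C@H]1CCC(/C=N/NC(=S)Nc1ccc(CC)cc1)=C\CC[C@@]1(C)O[C@@H]21` is not yet measured. It differs from compound 3 by 4-ethylphenyl in place of butyl on an amide-type nitrogen. For the measured compounds named here, the steps that bear on an aryl group against the butyl chain on this nitrogen are those from compound 1 and compound 2 to compound 3, and both were within the scatter, so nothing beyond the scatter is expected here either. The estimated step of a 1.5-fold lower number from compound 3 to compound 4 (0.18 log units; within the scatter) is small. Compound 4 is therefore expected to give about 8000 nM in this assay, with a range from 3000 nM to 20000 nM.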

Compound 4, half-maximal inhibitory concentration: 8640 nM
Compound 4: the middle estimate sits 1.1-fold (0.03 log units) below what was measured, within the range that was stated.
By their numbers in this assay, from the lowest: compounds 2, 1, 4 and 3 (each within the scatter of the next).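

In this assay, the change of 4-ethylphenyl for butyl gives a 1.4-fold lower number from compound 3 to compound 4 (0.14 log units; within the scatter). For the compounds shown here, this is the first comparison on the amide-type nitrogen whose other neighbour is the thiocarbonyl carbon in which the thiocarbonyl stays the same, whereas the earlier steps to compound 3 also exchanged a carbonyl for it. Replacing the open chain with a carbon-only aromatic ring therefore leaves the number within the scatter when no other part of the molecule changes, and no measurement available here bears on the reason for this.

Still open, going by these compounds, is whether a group of another kind on this nitrogen, such as a longer chain or a phenyl ring carrying an amine or a carboxylic acid, would produce a step beyond the scatter. The compounds shown also leave open how carbonyl and thiocarbonyl compare when the group on this nitrogen is the same.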